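Benzoxazole for benzothiazole in a cytotoxicity series

A few compounds are considered here, and "the series" means these few. Any claim that something is new, unique, unknown or untested is made for them only; others in the source may bear on it.

Compound 1, `Cc1cc(NC(=O)c2cc([N+](=O)[O-])ccc2Cl)cc(-c2nc3ccccc3o2)c1O`: > 25000 nM, a limit of the assay.
Compound 2, `Cc1cc(NC(=O)c2cc([N+](=O)[O-])ccc2Cl)cc(-c2nc3ccccc3s2)c1O`: > 25000 nM, a limit of the assay.
Compound 3, `Cc1ccc(-c2nc3ccccc3s2)cc1NC(=O)c1cc([N+](=O)[O-])ccc1Cl`: > 14000 nM, a limit of the assay.

The three compounds were tested in an ADME assay on HepG2 cells (Homo sapiens) for cytotoxicity, with a stated time of 72 h; on this read-out lower numbers stand for an effect already at smaller amounts and higher numbers for an effect only at larger amounts of compound. Within the data shown here, no compound gave a number; each result is a limit of the assay. Compound 1 sits at the limit of > 25000 nM in this assay, at which 2 of the 3 values shown sit. Compound 2 also sits at that limit. Compound 3 sits at the limit of > 14000 nM in this assay, at which 1 of the 3 values shown sits.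

Between compound 2 and compound 1 the change is 1,3-benzoxazol-2-yl in place of 1,3-benzothiazol-2-yl on an aromatic carbon. The step it made is a step that the two limits leave unreadable from compound 2 to compound 1, so its size cannot be read from the two limits.

The cores of compound 2 and compound 3 are not broken down here; the two differ in more than one place.

Compound 4, `Cc1ccc(-c2nc3ccccc3o2)cc1NC(=O)c1cc([N+](=O)[O-])ccc1Cl`, is not yet measured. From compound 3 to compound 4 the change is 1,3-benzoxazol-2-yl in place of 1,3-benzothiazol-2-yl on an aromatic carbon. It is the same kind of change as from compound 2 to compound 1, but the surroundings differ: in compound 2 the place is ortho to a hydroxy group and meta to a methyl group, whereas in compound 3 it is para to a methyl group.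

The expected step is a step that the limit leaves unreadable from compound 3 to compound 4, a small one, because the measured pair shows a step that the two limits leave unreadable from compound 2 to compound 1 and both of its members lie at limits. Compound 4 is therefore expected at 30000 nM, in the range 10000 nM to 100000 nM, most likely again reported only as a limit.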

Compound 4, half-maximal effective concentration: > 14000 nM
Compound 4 was reported as a limit; the forecaster's own chance of this, stated with the estimate: 85%; the middle value does not contradict the limit.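

In this assay compound 4 gives > 14000 nM, a limit of the assay. Among these compounds, compound 3 also stands at a limit, so no step from compound 3 to compound 4 can be read. The compounds shown leave open whether 1,3-benzoxazol-2-yl in place of 1,3-benzothiazol-2-yl changes this read-out at all, and at what concentration any of the four compounds would reach a half-maximal effect.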